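Swapping the Six-Membered Ring in Two Ester Series

The compounds below may be only part of what the source reports. "The series", "measured", "known", "first", "only" and "open" are said of these compounds alone.

Measured in a functional assay on Huh-7 cells (Homo sapiens) for cytotoxicity, read by MTT assay, with a stated time of 72 h; on this read-out lower numbers stand for higher toxicity in this test and higher numbers for lower toxicity in this test:
compound 1 `CCOC(=O)c1sc(Nc2ncccn2)nc1-c1cnccn1` gives 590 nM
compound 2 `CCOC(=O)c1sc(Nc2ncccn2)nc1-c1ccncn1` gives 1600 nM
compound 3 `CC(C)OC(=O)c1sc(Nc2ncccn2)nc1-c1cnccn1` gives 110 nM

Compound 4 `CC(C)OC(=O)c1sc(Nc2ncccn2)nc1-c1ccncn1` has not yet been measured in this assay. It differs from compound 3 by pyrimidin-4-yl in place of pyrazin-2-yl on an aromatic carbon. The same change, made from compound 1 to compound 2, gave a 2.7-fold higher number from compound 1 to compound 2 (0.43 log units; beyond the scatter). The cores of the two pairs differ by methyl in place of hydrogen on a saturated chain carbon bound to an oxygen next to a carbonyl group and a saturated chain carbon, a change that gave a 5.4-fold lower number from compound 1 to compound 3 (0.73 log units; beyond the scatter). The surroundings of the place are not identical: in one pair the ring atom next to it bears an ethoxycarbonyl group, in the other an isopropoxycarbonyl group, so the two changes are the same kind of change, not the same. Compound 3 stands lowest of the three measured numbers. The expected step is a 2.7-fold higher number from compound 3 to compound 4 (0.44 log units; beyond the scatter), resting on a 2.7-fold higher number from compound 1 to compound 2 (0.43 log units; beyond the scatter). Compound 4 is estimated at 300 nM, with a range from 120 nM to 800 nM.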

Compound 4, half-maximal cytotoxic concentration: 1210 nM
Compound 4: middle estimate off by 4.0-fold (0.61 log units), on the low side, outside the stated range (above it).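

In this assay, pyrimidin-4-yl in place of pyrazin-2-yl moved the number the same way on both cores, but the size of the step did not carry over to the isopropoxycarbonyl core, where it gave an 11-fold higher number from compound 3 to compound 4 (1.04 log units; beyond the scatter) and differed from the earlier step: the same change on two cores in this assay, a 2.7-fold higher number (0.43 log units; beyond the scatter) from compound 1 to compound 2 and an 11-fold higher number (1.04 log units; beyond the scatter) from compound 3 to compound 4, 4.1-fold (0.61 log units) apart, beyond the scatter of two such steps.
The change from ethoxycarbonyl to isopropoxycarbonyl also depended on the core, giving a 1.3-fold lower number from compound 2 to compound 4 (0.12 log units; within the scatter) on the pyrimidin-4-yl compounds, unlike its step on the pyrazin-2-yl compounds: the same change on two cores in this assay, a 5.4-fold lower number (0.73 log units; beyond the scatter) from compound 1 to compound 3 and a 1.3-fold lower number (0.12 log units; within the scatter) from compound 2 to compound 4, 4.1-fold (0.61 log units) apart, beyond the scatter of two such steps.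
The two changes therefore do not add up independently across these four compounds, but this single set of four does not show why, nor whether the same holds on other cores.

On these data alone, it remains open how a tert-butoxycarbonyl group or an amide in place of the ester would behave with each ring. As far as these compounds go, it is equally open whether a pyridin-2-yl ring at this place would follow either pattern.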